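The source may hold more compounds than are shown below. What is called first, only, known or untested is meant among the compounds shown, and "the series" means these compounds.

Series notes. Compound 1 `CCOC(=O)C1=C(Nc2ccccc2)S/C(=C\c2ccc(C(=O)O)cc2)C1=O` carries the shared core with a 4-carboxyphenyl group on the double-bonded chain carbon. In a functional assay on MCF7 cells (Homo sapiens) for inhibition, read by MTT assay, with a stated time of 72 h, tested at 10 uM (on this read-out lower numbers stand for less inhibition and higher numbers for more inhibition at the one concentration tested (going by the name of the read-out)), compound 1 gives only a limit, < 10%. Compound 2 `CCOC(=O)C1=C(Nc2ccccc2)S/C(=C\c2cc[nH]c2)C1=O` has 1H-pyrrol-3-yl in place of that group. In this assay compound 2 likewise gives only a limit, < 10%. The step that the two limits leave unreadable from compound 1 to compound 2 therefore cannot be sized. Compound 2 thus stands at the limit of this assay, and (the limit of < 10% in this assay, at which 2 of the 2 values shown sit), so nothing in the shown numbers sets compound 2 apart from compound 1.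

Compound 3 `CCOC(=O)C1=C(Nc2ccccc2)S/C(=C\c2cc3ncccc3[nH]2)C1=O` is not yet measured. It differs from compound 2 as follows: a group of 9 heavy atoms (7 carbon, 2 nitrogen; one five-membered aromatic ring with 1 hetero atom, one six-membered aromatic ring with 1 hetero atom) in place of a group of 5 heavy atoms (4 carbon, 1 nitrogen; one five-membered aromatic ring with 1 hetero atom), on a double-bonded chain carbon bound to a double-bonded ring carbon. Among the measured compounds shown here, the only step measured in this assay, from compound 1 to compound 2, is unreadable, so no measured step gives a direction or a size for a change at this position. Compound 3 is expected to stay near the limit in this assay. The expected step that the limit leaves unreadable from compound 2 to compound 3 is accordingly none beyond the scatter. Compound 3 is estimated at 8%, with a range from 0% to 25%.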

Compound 3, a percentage reported as inhibition, at one concentration (the size of the read-out at that concentration, not a potency): 42.2%
Estimate against measurement, compound 3: 34.2 percentage points below; measured number outside the range, above it.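

The position on the double-bonded chain carbon bound to a double-bonded ring carbon now responds in this assay: the change gives a number at least 32.2 percentage points higher from compound 2 to compound 3 (beyond the scatter), and replacing the 4-carboxyphenyl group gives a number at least 32.2 percentage points higher from compound 1 to compound 3 (beyond the scatter). Both the leaving 1H-pyrrol-3-yl and the entering group carry one five-membered aromatic ring with 1 hetero atom and 1 hydrogen-bond donor, while the entering group also has one six-membered aromatic ring with 1 hetero atom and 1 hydrogen-bond acceptor. The step from compound 1 to compound 2 still cannot be read, so every readable size at this position rests on compound 3, and the other two values remain limits of the assay: the limit of < 10% in this assay, at which 2 of the 3 values shown sit.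

The compounds shown do not separate the effect of the added six-membered ring from that of its nitrogen, and an indolyl group, whose six-membered ring is carbon only, would address that question. From the compounds shown here alone, it also remains open whether the gain depends on the ring nitrogen's place or persists with an amine or a longer chain on the entering group, and the single tested concentration gives no potency.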